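Aryl variation on the piperazine nitrogen, T-type channel series

The source may hold more compounds than are shown below. What is called first, only, known or untested is meant among the compounds shown, and "the series" means these compounds.

Measured so far:
compound 1 `CCCc1nc(-c2ccccc2)c(CNCCN2CCN(c3ccc(Cl)cc3)CC2)o1` – 2820 nM
compound 2 `CCCc1nc(-c2ccccc2)c(CNCCN2CCN(c3cccc(C(F)(F)F)c3)CC2)o1` – 1940 nM

Compounds 1 and 2 share one core and differ only in the aryl group carried on an amine nitrogen in a ring. In an assay on HEK293 cells for inhibition of Voltage-dependent T-type calcium channel subunit alpha-1G (Homo sapiens), read by patch clamp (on this read-out higher numbers stand for weaker inhibition and lower numbers for stronger inhibition), compound 1 gives 2820 nM, and in this assay compound 2 gives 1940 nM. Within the data shown here, the single step measured so far, a 1.5-fold lower number from compound 1 to compound 2 (0.16 log units; within the scatter), is within the scatter. Among the measured compounds shown here, compound 2 thus stands with the lowest of the two numbers, but its only neighbour, compound 1, sits within the scatter of it, so no order between the two can be claimed.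

Compound 3 `CCCc1nc(-c2ccccc2)c(CNCCN2CCN(c3ccccc3Cl)CC2)o1` is not yet measured. It carries 2-chlorophenyl in place of 3-(trifluoromethyl)phenyl on an amine nitrogen in a ring. For the measured compounds named here, the only step that bears on this change is the one from compound 1 to compound 2, which also exchanged one aryl group for another at the same ring nitrogen and gave a number within the scatter. On that basis no step beyond the scatter is expected for compound 3 in this assay; the expected step is a 1.2-fold higher number from compound 2 to compound 3 (0.09 log units; within the scatter). Compound 3 is therefore estimated at 2400 nM, with a range from 1000 nM to 6000 nM.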

Compound 3, half-maximal inhibitory concentration: 4370 nM
Compound 3: the middle estimate sits 1.8-fold (0.26 log units) below what was measured; the measured number falls inside the stated range.
By their numbers in this assay, from the lowest: compounds 2, 1 and 3 (each within the scatter of the next, the first and the last beyond it).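

In this assay, among these compounds, the exchange of 3-(trifluoromethyl)phenyl for 2-chlorophenyl gives a 2.3-fold higher number from compound 2 to compound 3 (0.35 log units; beyond the scatter) and this is the one step at this ring nitrogen that lies beyond the scatter, which shows that the aryl group carried here can shift the number, though only modestly. Among the compounds shown here, the exchange of 4-chlorophenyl for 2-chlorophenyl gives a 1.5-fold higher number from compound 1 to compound 3 (0.19 log units; within the scatter) and so does not separate these two chlorophenyl groups, while compound 1 also sits within the scatter of compound 2, leaving the two ends of the series as the only pair that can be told apart. No measurement at hand accounts for the step beyond the scatter.

Still open, on these data alone, is whether that step belongs to the exchange of trifluoromethyl for chlorine or to where the group sits on the phenyl ring, a question that 3-chlorophenyl at this nitrogen would bear on directly. Also open, as far as these compounds go, is how far the number moves with a plain phenyl, a methoxy-bearing phenyl or a pyridine ring on this nitrogen.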